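Cytotoxicity notes on a linked series, compound 4 estimate

The source may hold more compounds than are shown below. What is called first, only, known or untested is meant among the compounds shown, and "the series" means these compounds.

In an ADME assay on L02 cells (Homo sapiens) for cytotoxicity, read by MTT assay, with a stated time of 48 h (a lower number here means a stronger inhibitor, a higher number a weaker inhibitor), the three measured compounds are:
compound 1 `COc1cc2ccc(=O)oc2cc1OCCOc1no[n+]([O-])c1S(=O)(=O)c1ccccc1`: 10900 nM
compound 2 `COc1cc2ccc(=O)oc2cc1OCCCCOc1no[n+]([O-])c1S(=O)(=O)c1ccccc1`: 9330 nM
compound 3 `COc1cc2cc(NC(C)=O)c(=O)oc2cc1OCCCCOc1no[n+]([O-])c1S(=O)(=O)c1ccccc1`: 9190 nM

Among the three numbers compound 3 carries the lowest, but its gaps to compound 2 and to compound 1 both lie within the scatter, so no difference between the three can be claimed. Among the compounds with values here, the only single-place step, a 1.0-fold lower number from compound 2 to compound 3 (0.01 log units; within the scatter), shows acetamido in place of hydrogen on an aromatic carbon leaving this assay unchanged. Compound 4 `COc1cc2cc(N)c(=O)oc2cc1OCCCCOc1no[n+]([O-])c1S(=O)(=O)c1ccccc1` differs from compound 3 by hydrogen in place of acetyl on a nitrogen on an aromatic ring. Within the data shown here, no measured step removes an acetyl from such a nitrogen, so this change has no direct precedent; with the one related step inside the scatter, no step beyond the scatter is expected, a 1.0-fold lower number from compound 3 to compound 4 (0.01 log units; within the scatter). Compound 4 is therefore estimated at 9000 nM, range 4500 nM to 18000 nM.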

Compound 4, half-maximal inhibitory concentration: 8630 nM
For compound 4 the middle estimate is 1.0-fold (0.02 log units) above the measured one; measured number inside the range.
By their numbers in this assay, from the lowest: compounds 4, 3, 2 and 1 (each within the scatter of the next).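

In this assay this aromatic carbon now carries hydrogen, amino or acetamido with no separation beyond the scatter: amino in place of hydrogen gives (a 1.1-fold lower number from compound 2 to compound 4 (0.03 log units; within the scatter)), and hydrogen in place of acetyl on the nitrogen gives (a 1.1-fold lower number from compound 3 to compound 4 (0.03 log units; within the scatter)). The acetyl can therefore go without a step beyond the scatter, and the free amino group reads the same as the acetamido group here. Still open, as far as these compounds go, is whether a benzoyl group on this nitrogen, or a carboxylic acid on this carbon, would move the number. Nothing available explains this flat result.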